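Chloro to bromo on the formyl-bearing core, compound 3 to 4

The source may hold more compounds than are shown below. What is called first, only, known or untested is meant among the compounds shown, and "the series" means these compounds.

Measured so far:
compound 1 `Cc1ccc2c(Cc3nn4cc(-c5ccc(Cl)cc5)nc4s3)coc2c1` gives 55.9%
compound 2 `Cc1ccc2c(Cc3nn4cc(-c5ccc(Br)cc5)nc4s3)coc2c1` gives 11.1%
compound 3 `Cc1ccc2c(Cc3nn4c(C=O)c(-c5ccc(Cl)cc5)nc4s3)coc2c1` gives 47.2%

These three were read in a functional assay on the whole organism (strain Wistar albino) for inhibition, with Rattus norvegicus as the target, read by paw edema, with a stated time of 4 h, at a dose of 100 mg/kg by the oral route; on this read-out lower numbers stand for less inhibition and higher numbers for more inhibition at the one dose given (going by the name of the read-out). Compound 3 stands second highest of the three numbers: compound 1 sits nearest, the gap being a number 8.7 percentage points lower from compound 1 to compound 3 (within the scatter) and so within the scatter, while compound 2 sits furthest below it, a gap beyond the scatter.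

The next compound, compound 4 `Cc1ccc2c(Cc3nn4c(C=O)c(-c5ccc(Br)cc5)nc4s3)coc2c1`, is not yet measured. It differs from compound 3 by bromo in place of chloro on an aromatic carbon on an aromatic carbon of a six-membered aromatic ring of carbon only, para to a large group; cut one bond further out, 4-chlorophenyl becomes 4-bromophenyl.

Within the data shown here, one measured step bears on this change directly: a number 44.8 percentage points lower from compound 1 to compound 2 (beyond the scatter), the same swap on the core without formyl. The formyl itself moved little, a number 8.7 percentage points lower from compound 1 to compound 3 (within the scatter). If the swap behaves the same way on the formyl-bearing core, a large drop is to be expected in this assay, in the downward direction, well beyond the scatter. No case goes against this within the series, though it rests on a single pair.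

Compound 4 is therefore expected to give about 8%, in the range 0% to 28%, which is the estimated step of a number 39.2 percentage points lower from compound 3 to compound 4 (beyond the scatter).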

Compound 4, a percentage reported as inhibition, in the whole organism at one dose (the size of the read-out at that dose, not a potency): 10.3%
Compound 4: the middle estimate sits 2.3 percentage points below what was measured; the measured number falls inside the stated range.
By their numbers in this assay, from the lowest: compounds 4 and 2 (each within the scatter of the next); then compounds 3 and 1 (each within the scatter of the next).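

In this assay, the swap of chloro for bromo on the phenyl ring now has a second case, a number 36.9 percentage points lower from compound 3 to compound 4 (beyond the scatter), so the large loss is not confined to the core without formyl: the same change on two cores in this assay, a number 44.8 percentage points lower (beyond the scatter) from compound 1 to compound 2 and a number 36.9 percentage points lower (beyond the scatter) from compound 3 to compound 4, 7.9 percentage points apart, within the scatter of two such steps

Formyl in place of hydrogen can now also be read with bromo on the ring, a number 0.8 percentage points lower from compound 2 to compound 4 (within the scatter), and it stays within the scatter with either halogen: the same change on two cores in this assay, a number 8.7 percentage points lower (within the scatter) from compound 1 to compound 3 and a number 0.8 percentage points lower (within the scatter) from compound 2 to compound 4, 7.9 percentage points apart, within the scatter of two such steps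

Across these four compounds, the large steps come with the chloro-to-bromo swap and not with the formyl swap, and no compound goes against this.

The compounds shown leave open how a methoxy group, an amine or a fluoro group would read at the place para to a large group, so two halogens are all that describe this position. They also leave open whether a carboxylic acid or a hydroxymethyl group in place of formyl would stay as close to the hydrogen compound, and each number here describes a single dose and a single time.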